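The compounds below may be only part of what the source reports. "The series", "measured", "known", "first", "only" and "open" are said of these compounds alone.

Series so far, in a functional assay on HCT-116 cells (Homo sapiens) for antiproliferative activity, read by MTT assay, with a stated time of 48 h; on this read-out lower numbers stand for stronger inhibition and higher numbers for weaker inhibition:

- Compound 1 `CCCCCC(CCO)n1cnc2c(N)ncnc21`: > 50000 nM, a limit
- Compound 2 `CCCCCCCC(CCO)n1cnc2c(N)ncnc21`: > 50000 nM, a limit
- Compound 3 `CCCCCCCCCCCC(CCO)n1cnc2c(N(C)C)ncnc21`: 12000 nM

Among the measured compounds shown here, compound 3 at 12000 nM holds the only true number. The other two entries are limits and give no position on the scale.

The next comparison is compound 4 `CCCCCCCCCCCC(CCO)n1cnc2c(N)ncnc21`. Its difference from compound 3 is amino in place of dimethylamino on an aromatic carbon and the chain of compound 3 stays as it is. Compound 4 thus carries the amino group of compound 1 and compound 2.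

For the measured compounds named here, no measured step covers this exchange. Going by the values given here, the one step available, a step that the two limits leave unreadable from compound 1 to compound 2, has no size that can be carried over. Compound 1 and compound 2 both stand at the limit of > 50000 nM in this assay, at which 2 of the 3 values shown sit, so the amino compounds offer no number to work from, and they differ from compound 4 in the chain.

The expectation therefore rests on compound 3 at 12000 nM, with no clear direction set by the data in this assay. The expected change is a 1.3-fold higher number from compound 3 to compound 4 (0.12 log units; within the scatter), an estimate with wide uncertainty, and a limit reading cannot be ruled out. For compound 4 the estimated value is 16000 nM, with an expected range of 6000 nM to 45000 nM.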

Compound 4, half-maximal inhibitory concentration: 13400 nM
Estimate against measurement, compound 4: 1.2-fold (0.08 log units) above, and the stated range covers the measured number.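

In this assay, this aromatic carbon gets its first readable test with the chain held fixed, a 1.1-fold higher number from compound 3 to compound 4 (0.05 log units; within the scatter), so amino and dimethylamino at this place stand within the scatter of each other. With amino held fixed, the chain gives the first differences in the amino compounds that reach beyond the scatter, an at least 3.7-fold lower number from compound 2 to compound 4 (0.57 log units; beyond the scatter) and an at least 3.7-fold lower number from compound 1 to compound 4 (0.57 log units; beyond the scatter), so in these compounds the chain separates values where the exchange on the aromatic carbon does not. Compound 1 and compound 2 each stand at a limit, so these two steps have no full size, and the step between those two compounds cannot be read: the limit of > 50000 nM in this assay, at which 2 of the 4 values shown sit.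

The compounds shown leave open whether amino and dimethylamino would also stand within the scatter of each other on a shorter chain, as dimethylamino appears here only on the chain of compound 3. Also open, on these data alone, are the reading for methylamino on the same aromatic carbon and whether a longer chain than that of compound 4 would give a lower number in this assay.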